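Series notes: removing the hydroxy from compound 3

This account rests on a few compounds, and the source may have more. Where it says the series, first, only, none or still open, it means among the compounds named here.

Compound 1 `O=C(O)c1ccccc1-c1ccc(CCc2ncc(Cc3ccccc3F)[nH]2)cc1` gives 9.5 nM in an in vitro functional assay on cells for agonist activity at Bombesin receptor subtype-3 (Mus musculus), read by luminescence and calcium flux (a higher number here means that more compound is needed for the effect, a lower number that less compound is needed), compound 2 `O=C(O)c1ccccc1-c1ccc(CCc2ncc(CCC3CCCCC3)[nH]2)cc1` gives 33 nM, and compound 3 `CCCCc1cnc(C(CCCO)Cc2ccc(-c3ccccc3C(=O)O)cc2)[nH]1` gives 238 nM, the highest of the three numbers. Within the data shown here, the only one-place step measured so far is a 3.5-fold higher number from compound 1 to compound 2 (0.54 log units; beyond the scatter), a change on a different part of the molecule. Compound 4 `CCCCc1cnc(C(CCC)Cc2ccc(-c3ccccc3C(=O)O)cc2)[nH]1` differs from compound 3 by hydrogen in place of hydroxy on a saturated chain carbon, four bonds along the chain from an aromatic carbon. Among the measured compounds shown here, no measured step touches a hydroxy, so nothing in the set speaks to this change, and the expectation is a step no larger than the scatter, a 1.1-fold lower number from compound 3 to compound 4 (0.03 log units; within the scatter). Going by these compounds, compound 4 is therefore estimated at 220 nM, with a range from 60 nM to 800 nM, the width reflecting that the step itself is untested.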

Compound 4, half-maximal effective concentration: 165 nM
Compound 4: middle estimate off by 1.3-fold (0.12 log units), on the high side; measured number inside the range.
By their numbers in this assay, from the lowest: compound 1; then compound 2; then compounds 4 and 3 (each within the scatter of the next).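

Taking the hydroxy off the 3-hydroxypropyl to leave propyl stays within the scatter in this assay (a 1.4-fold lower number from compound 3 to compound 4 (0.16 log units; within the scatter)). For this pair, the hydroxy on this chain is therefore not required for the agonist read-out, and compound 3 and compound 4 cannot be separated. No supporting evidence bears on this step.

Still open, going by these compounds, is whether an amine or a carboxylic acid at the end of this chain would move the number beyond the scatter. A longer chain at the same place is equally unresolved.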